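The source may hold more compounds than are shown below. What is called first, only, known or untested is meant among the compounds shown, and "the series" means these compounds.

In an ADME assay (liver) for metabolic stability, with Liver microsome (Homo sapiens) as the target, using microsomes and NADPH, with a stated time of 30 min, tested at 1 uM (a higher number here means faster removal of the compound, a lower number slower removal), compound 3 `Cc1nc2cc(-c3cc(C(O)(C(F)(F)F)C(F)(F)F)cnc3N3CCN(S(=O)(=O)c4ccc(N)nc4)CC3)ccc2o1` gives < 14 mL.min-1.g-1, which is a limit of the assay and not a number. That places compound 3 at the limit of < 14 mL.min-1.g-1 in this assay, at which 1 of the 3 values shown sits. Two relatives with the same core gave numbers: compound 1 `Nc1ccc(S(=O)(=O)N2CCN(c3ncc(C(O)(C(F)(F)F)C(F)(F)F)cc3-c3cccnc3)CC2)cn1` gives 17 mL.min-1.g-1 and compound 2 `Nc1ccc(S(=O)(=O)N2CCN(c3ncc(C(O)(C(F)(F)F)C(F)(F)F)cc3-c3ccc4sccc4c3)CC2)cn1` gives 48 mL.min-1.g-1. Compound 4 `Nc1ccc(S(=O)(=O)N2CCN(c3ncc(C(O)(C(F)(F)F)C(F)(F)F)cc3-c3cc4ccccc4[nH]3)CC2)cn1` carries 1H-indol-2-yl in place of 2-methyl-1,3-benzoxazol-5-yl, a change summarised as 1H-indol-2-yl in place of 2-methyl-1,3-benzoxazol-5-yl on an aromatic carbon. Within the data shown here, no measured step makes this exact swap, but three steps change the same aromatic carbon. Placing 1-benzothiophen-5-yl there gave a 2.8-fold higher number from compound 1 to compound 2 (0.45 log units; beyond the scatter), while 2-methyl-1,3-benzoxazol-5-yl gave an at least 1.2-fold lower number from compound 1 to compound 3 (0.08 log units; that floor lies within the scatter) and an at least 3.4-fold lower number from compound 2 to compound 3 (0.53 log units; beyond the scatter). The nearest measured group to 1H-indol-2-yl appears to be the 1-benzothiophen-5-yl of compound 2 at 48 mL.min-1.g-1, so a modest rise is expected rather than no change. The expected size of the move is an at least 2.2-fold higher number from compound 3 to compound 4 (0.35 log units; beyond the scatter). The estimated value for compound 4 is 32 mL.min-1.g-1, with an expected range from 15 mL.min-1.g-1 to 70 mL.min-1.g-1.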

Compound 4, intrinsic clearance in microsomes: < 14 mL.min-1.g-1
Compound 4 ended at the assay's limit (the forecaster's own chance of this, stated with the estimate: 10%); at least 2.2-fold (0.35 log units) between middle value and limit.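

In this assay compound 4 gives < 14 mL.min-1.g-1, which is a limit of the assay and not a number. The 1H-indol-2-yl group brings an at least 3.4-fold lower number from compound 2 to compound 4 (0.53 log units; beyond the scatter), so the higher number of compound 2 does not come with every fused aromatic group on this carbon. The step to the pyridin-3-yl compound is an at least 1.2-fold lower number from compound 1 to compound 4 (0.08 log units; that floor lies within the scatter), so no real difference from that compound can be claimed, and the step between compound 3 and compound 4 cannot be read, since both rest on the same floor: the limit of < 14 mL.min-1.g-1 in this assay, at which 2 of the 4 values shown sit.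

On these data alone, how far compound 3 and compound 4 truly lie under that limit stays unknown, as does whether the hydrogen-bond donor of the 1H-indol-2-yl group plays any part. The compounds shown also leave open how an amine or a carboxylic acid on this aromatic carbon would behave.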